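Bromo for Fluoro on a Chalcone Amide

A few compounds are considered here, and "the series" means these few. Any claim that something is new, unique, unknown or untested is made for them only; others in the source may bear on it.

Compound 1 `O=C1OCC[C@@H]1NC(=S)SCCOc1ccccc1` reaches only the limit > 64000 nM in a functional assay on PC-3 cells (Homo sapiens) for antiproliferative activity, read by MTT assay, with a stated time of 72 h (on this read-out higher numbers stand for weaker inhibition and lower numbers for stronger inhibition), a limit rather than a number.
Compound 2 `O=C(COc1ccc(C(=O)/C=C/c2ccc(F)cc2)cc1)N[C@H]1CCOC1=O` gives 15600 nM in this assay.

For the measured compounds named here, compound 2 thus holds the only numerical value, while compound 1 sits at the limit of > 64000 nM in this assay, at which 1 of the 2 values shown sits. Compound 3 `O=C(COc1ccc(C(=O)/C=C/c2ccc(Br)cc2)cc1)N[C@H]1CCOC1=O` differs from compound 2 by bromo in place of fluoro on an aromatic carbon, para to a large group. Going by the values given here, no measured pair shares this change, so the step stays open; a modest move toward stronger inhibition, near the edge of the scatter, is expected as a 2.0-fold lower number from compound 2 to compound 3 (0.29 log units; within the scatter). Compound 3 is accordingly estimated at 8000 nM, between 3000 nM and 30000 nM.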

Compound 3, half-maximal inhibitory concentration: > 64000 nM
Compound 3 ended at the assay's limit (the forecaster's own chance of this, stated with the estimate: 5%); at least 8.0-fold (0.90 log units) between middle value and limit.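

On the aromatic carbon para to a large group, this position does not tolerate every halogen alike: in this assay, replacing fluoro with bromo gives an at least 4.1-fold higher number from compound 2 to compound 3 (0.61 log units; beyond the scatter). The step is a bound and not an exact size, since compound 3 stands at a limit of the assay, not at a number: the limit of > 64000 nM in this assay, at which 2 of the 3 values shown sit.

The compounds shown leave open how chloro, methyl or methoxy would read at this place. They also leave open whether a 4-fluorophenyl group keeps its activity when the lactone is replaced by an open-chain carboxylic acid.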